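Shifting a Hydroxyl on the Sulfonyl Aryl Ring

The source may report more compounds than this note shows. Statements on the series, on what has been measured and on what is new or still open speak of the compounds shown alone.

Compound 1 `O=S(=O)(Nc1ccc2oc(-c3ccccc3)nc2c1)c1ccccc1Cl` was tested in an assay on cells for inhibition of HSP60/HSP10 (Homo sapiens), with a stated time of 60 min (on this read-out lower numbers stand for stronger inhibition and higher numbers for weaker inhibition), and reached only the assay limit, > 100000 nM. Compound 2 `O=S(=O)(Nc1ccc2oc(-c3ccccc3)nc2c1)c1ccc(O)cc1` gives 88000 nM in this assay. Within the data shown here, the step of an at least 1.1-fold lower number from compound 1 to compound 2 (0.05 log units; that floor lies within the scatter) is the sole measured change, and its floor follows from the limit of > 100000 nM in this assay, at which 1 of the 2 values shown sits. Compound 2 therefore stands alone as the one number shown; the other entry is a limit. Compound 3 `O=S(=O)(Nc1ccc2oc(-c3ccccc3)nc2c1)c1ccccc1O` differs from compound 2 by 2-hydroxyphenyl in place of 4-hydroxyphenyl on a sulfonyl sulfur. Among the measured compounds shown here, the only step bearing on this change is an at least 1.1-fold lower number from compound 1 to compound 2 (0.05 log units; that floor lies within the scatter), which swapped the whole aryl group on the sulfonyl sulfur and was no larger than the scatter allows. For the measured compounds named here, no measured step separates two hydroxyphenyl groups from each other, so no shift beyond the scatter in this assay is expected. Compound 3 is estimated at 90000 nM, with a range from 35000 nM to 250000 nM. The expected step is a 1.0-fold higher number from compound 2 to compound 3 (0.01 log units; within the scatter).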

Compound 3, half-maximal inhibitory concentration: 85000 nM
The estimate for compound 3 lay 1.1-fold (0.02 log units) above the measured number; low and high end bracket the measured number.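

Exchanging 4-hydroxyphenyl for 2-hydroxyphenyl on the sulfonyl sulfur gives a 1.0-fold lower number from compound 2 to compound 3 (0.02 log units; within the scatter) in this assay, so on this read-out the two hydroxyphenyl groups cannot be told apart. Hydroxy in place of chloro on an aromatic carbon gives an at least 1.1-fold lower number from compound 1 to compound 3 (0.07 log units; that floor lies within the scatter), so this exchange, made within a single ring position, also shows no shift beyond the scatter. Compound 1 gives a limit and not a number, so that step is only a floor and its true size stays unknown: the limit of > 100000 nM in this assay, at which 1 of the 3 values shown sits.

The compounds shown leave open whether an amine or a carboxylic acid in place of the hydroxy group on this ring would give a number clearly lower than these. Going by these compounds, whether a change to the core of compound 1, rather than to this ring, would move the read-out also remains open.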